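Fluorine for Hydrogen: Expected Cytotoxicity of Compound 3

This account rests on a few compounds, and the source may have more. Where it says the series, first, only, none or still open, it means among the compounds named here.

Two compounds have been run in an ADME assay on Vero cells (Chlorocebus sabaeus) for cytotoxicity, read by fluorescence and resazurin assay, with a stated time of 3 days; on this read-out lower numbers stand for higher toxicity in this test and higher numbers for lower toxicity in this test. Compound 1 `CC1(C)O[C@H]2O[C@H](Cn3cc(CN4C(=O)C(=O)c5ccccc54)nn3)[C@H](O)[C@H]2O1` reached only the limit of the assay, > 200000 nM. Among the measured compounds shown here, compound 2 `CC(=O)C[C@H]1O[C@@H](On2cc(CN3C(=O)/C(=N\Nc4ccccc4)c4ccccc43)nn2)[C@H](OC(C)=O)[C@@H](OC(C)=O)[C@@H]1OC(C)=O` is the one compound with an actual number in this assay, where compound 2 gives 108000 nM. Compound 3 `CC(=O)C[C@H]1O[C@@H](On2cc(CN3C(=O)/C(=N\Nc4ccc(F)cc4)c4ccccc43)nn2)[C@H](OC(C)=O)[C@@H](OC(C)=O)[C@@H]1OC(C)=O` differs from compound 2 by fluoro in place of hydrogen on an aromatic carbon. No measured step of this kind exists among the shown compounds, so the expectation rests on the change alone. In this assay the step of a 1.2-fold lower number from compound 2 to compound 3 (0.08 log units; within the scatter) is expected to stay within the usual scatter. Compound 3 is therefore estimated at 90000 nM, with a range from 40000 nM to 200000 nM.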

Compound 3, half-maximal cytotoxic concentration: 68700 nM
The estimate for compound 3 lay 1.3-fold (0.12 log units) above the measured number, within the range that was stated.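

In this assay the change from phenyl to 4-fluorophenyl gives a 1.6-fold lower number from compound 2 to compound 3 (0.20 log units; within the scatter) and so shows that this one replacement, para to a large group, stays within the scatter. Among the compounds shown here, the two compounds thus remain indistinguishable in this test, which the earlier compounds alone could not show. For the compounds shown here, compound 1 stands at a limit, not at a number, and enters no step: the limit of > 200000 nM in this assay, at which 1 of the 3 values shown sits.

On these data alone, whether a larger group at this place, such as an amine, a methoxy group or a carboxylic acid, would move the number beyond the scatter stays open. So does the effect of fluoro at other carbons of this ring.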